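A few compounds are considered here, and "the series" means these few. Any claim that something is new, unique, unknown or untested is made for them only; others in the source may bear on it.

Of the compounds shown here, two have numbers so far. Compound 1 `COc1cc(C(=O)O)nc2ccc(-c3ccc(OCc4c(-c5c(Cl)cccc5Cl)noc4C(C)C)cc3)cc12` gives 17 nM in a functional assay on CV-1 cells for agonist activity at Bile acid receptor (Homo sapiens), read by a luciferase reporter; a lower number here means that less compound is needed, a higher number that more compound is needed for the effect. Compound 2 `CCCOc1cc(C(=O)O)nc2ccc(-c3ccc(OCc4c(-c5c(Cl)cccc5Cl)noc4C(C)C)cc3)cc12` carries propoxy where compound 1 carries methoxy. In this assay compound 2 gives 22 nM. The step of a 1.3-fold higher number from compound 1 to compound 2 (0.11 log units; within the scatter) lies within the scatter, so compound 2 stands alongside compound 1, with no separation that the measurement can support.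

Compound 3 `CC(C)COc1cc(C(=O)O)nc2ccc(-c3ccc(OCc4c(-c5c(Cl)cccc5Cl)noc4C(C)C)cc3)cc12` is not yet measured. It differs from compound 2 by methyl in place of hydrogen on a saturated chain carbon bound to two saturated chain carbons. For the measured compounds named here, the only measured step that bears on this change is a 1.3-fold higher number from compound 1 to compound 2 (0.11 log units; within the scatter), a growth of the same chain on the ring oxygen, which stayed within the scatter. For compound 3 the branching is therefore expected to give no step beyond the scatter, a 1.1-fold higher number from compound 2 to compound 3 (0.06 log units; within the scatter). Compound 3 is estimated at 25 nM in this assay, with a range from 10 nM to 60 nM.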

Compound 3, half-maximal effective concentration: 81 nM
For compound 3 the middle estimate is 3.2-fold (0.51 log units) below the measured one; the whole stated range lies below it.
By their numbers in this assay, from the lowest: compounds 1 and 2 (each within the scatter of the next); then compound 3.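

In this assay, for the compounds shown here, the chain on the ring oxygen proves sensitive to change after all: methyl in place of hydrogen on a saturated chain carbon bound to two saturated chain carbons, propoxy to isobutoxy, gives a 3.7-fold higher number from compound 2 to compound 3 (0.57 log units; beyond the scatter), the first step beyond the scatter. Measured against the methoxy chain, the same picture holds, with a 4.8-fold higher number from compound 1 to compound 3 (0.68 log units; beyond the scatter), so the tolerance seen on going from methoxy to propoxy does not carry over to isobutoxy. No measurement at hand speaks to the reason for this step.

From the compounds shown here alone, a straight butoxy chain on the ring oxygen would show whether the branch or the added carbon matters here, and that remains open. Also open, going by these compounds, is how this position responds to a chain ending in an amine or a hydroxyl.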